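Swapping cyclopropyl for 4-methoxyphenyl on two related cores

The source may hold more compounds than are shown below. What is called first, only, known or untested is meant among the compounds shown, and "the series" means these compounds.

Compound 1 `COc1ncc(-c2ccc3c(c2)N(C2CC2)C(=O)CO3)cc1NS(=O)(=O)c1ccc(F)cc1` and compound 3 `COc1ccc(N2C(=O)COc3ccc(-c4cnc(OC)c(NS(=O)(=O)c5ccc(F)cc5)c4)cc32)cc1` share one core and differ in that (4-methoxyphenyl in place of cyclopropyl on an amide-type nitrogen in a ring). In a functional assay on A-375 cells (Homo sapiens) for antiproliferative activity, read by MTT assay, with a stated time of 72 h (a higher number here means a weaker inhibitor, a lower number a stronger inhibitor), compound 1 gives 23900 nM. In this assay compound 3 gives 18400 nM, so that a 1.3-fold lower number from compound 1 to compound 3 (0.11 log units; within the scatter). Compound 2 `O=C1COc2ccc(-c3cccc(NS(=O)(=O)c4ccc(F)cc4)c3)cc2N1C1CC1` is built on another core; the difference between the two cores is not broken down here. In this assay compound 2 reaches only a limit of the assay, > 40000 nM, which is the limit of > 40000 nM in this assay, at which 1 of the 3 values shown sits. Compound 4 `COc1ccc(N2C(=O)COc3ccc(-c4cccc(NS(=O)(=O)c5ccc(F)cc5)c4)cc32)cc1` differs from compound 2 in that (4-methoxyphenyl in place of cyclopropyl on an amide-type nitrogen in a ring), the same change as between compound 1 and compound 3. Because that change gave a 1.3-fold lower number from compound 1 to compound 3 (0.11 log units; within the scatter), compound 4 is expected to stay close to its parent, with a step that the limit leaves unreadable from compound 2 to compound 4. Compound 4 is accordingly estimated at 42000 nM, between 20000 nM and 100000 nM, and may again be reported only as a limit.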

Compound 4, half-maximal inhibitory concentration: 38500 nM
Estimate against measurement, compound 4: 1.1-fold (0.04 log units) above; the range from low to high includes it.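

In this assay, placing 4-methoxyphenyl in place of cyclopropyl on the amide-type nitrogen gives an at least 1.0-fold lower number from compound 2 to compound 4 (0.01 log units; that floor lies within the scatter). For compound 2, the value > 40000 nM is a limit of the assay and not a number. The series therefore shows no step beyond the scatter on either core, but it does not show whether the change carries over from one core to the other at the same size: the same change on two cores in this assay, a 1.3-fold lower number (0.11 log units; within the scatter) from compound 1 to compound 3 and an at least 1.0-fold lower number (0.01 log units; that floor lies within the scatter) from compound 2 to compound 4; the limit leaves it open whether they differ.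

The compounds shown leave open how a longer chain, an amine or a carboxylic acid on that amide-type nitrogen would read in this assay. They also leave open how large the step from compound 2 to compound 4 actually is.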